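The source may report more compounds than this note shows. Statements on the series, on what has been measured and on what is new or still open speak of the compounds shown alone.

Compound 1 `O=C(O)C[C@H](O)C[C@H](O)CCn1c(-c2ccc(F)cc2)nc(C(=O)NCc2ccc(F)c(F)c2)c1C1CC1` and compound 2 `CCc1c(C(=O)NCc2ccccc2)nc(-c2ccc(F)cc2)n1CC[C@@H](O)C[C@@H](O)CC(=O)O` share the same core and the same acid-bearing side chain; they differ in the group on the core and in the substituted benzyl amide. In an assay on microsomes from liver for inhibition of 3-hydroxy-3-methylglutaryl-coenzyme A reductase (Rattus norvegicus), read by scintillation counting, with stated times of 0.5 h and 0.75 h (a higher number here means a weaker inhibitor, a lower number a stronger inhibitor), compound 1 gives 1.2 nM, the lower of the two numbers on record, while compound 2 gives 123 nM, a gap that lies well beyond the usual scatter of repeated measurements. Since compound 2 differs from compound 1 in two places at once, those two values show only what the pair of changes together does, not what each one does alone.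

Compound 3 `COc1ccccc1CNC(=O)c1nc(-c2ccc(F)cc2)n(CC[C@@H](O)C[C@@H](O)CC(=O)O)c1C1CC1` has not been measured. It differs from compound 1 in a single place: 2-methoxyphenyl in place of 3,4-difluorophenyl on a saturated chain carbon bound to an amide-type nitrogen. For the measured compounds named here, no step between measured compounds that differ in one place is known, so the size of this change cannot be read from a direct precedent. Because compound 1 gives 1.2 nM, compound 3 is expected to remain a strong inhibitor, with a modest loss of potency estimated as a 3.3-fold higher number from compound 1 to compound 3 (0.52 log units; beyond the scatter) in this assay. Compound 3 is therefore estimated at 4 nM, with an expected range from 1 nM to 20 nM.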

Compound 3, half-maximal inhibitory concentration: 7 nM
Compound 3: middle estimate off by 1.8-fold (0.24 log units), on the low side; measured number inside the range.
By their numbers in this assay, from the lowest: compound 1; then compound 3; then compound 2.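

In this assay the step gives a 5.8-fold higher number from compound 1 to compound 3 (0.77 log units; beyond the scatter), the first change seen at this position with the rest of the molecule held fixed, so the effect of this group can now be read on its own. The step is modest but beyond the usual scatter: this place responds to what the aromatic ring carries, yet a ring with quite different substituents still leaves compound 3 a strong inhibitor, even though both groups hold 8 heavy atoms and only the entering 2-methoxyphenyl counts a hydrogen-bond acceptor. Nothing shown explains the loss of potency, and no measurement of any property of these groups bears on it.

As far as these compounds go, this single swap removes two fluorines and adds a methoxy group in one move, so the share of each in the step stays unknown. From the compounds shown here alone, a group such as 3-fluorophenyl or 2-chlorophenyl at the same place would help separate those parts, and the separate effect of the cyclopropyl group on the core also remains open.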